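The source may report more compounds than this note shows. Statements on the series, on what has been measured and on what is new or still open speak of the compounds shown alone.

Of the compounds shown here, three have been measured in an assay for positive allosteric modulation of metabotropic glutamate receptor 2 (Rattus norvegicus); a lower number here means that less compound is needed, a higher number that more compound is needed for the effect. Compound 1 `Cc1c(OCCCCOc2ccc(Cl)c(C(=O)O)c2)ccc(C(=O)CC(C)(C)C)c1O` gives 87 nM. Compound 2 `COc1ccc(OCCCCOc2ccc(C(=O)CC(C)(C)C)c(O)c2C)cc1C(=O)O` differs from compound 1 in one place: methoxy in place of chloro on an aromatic carbon. Compound 2 gives 13 nM, and the step of a 6.7-fold lower number from compound 1 to compound 2 (0.83 log units; beyond the scatter). Compound 3 `Cc1c(OC[C@@H](C)COc2ccc(C(=O)O)c(Cl)c2)ccc(C(=O)CC(C)(C)C)c1O` has the same atoms as compound 1 joined differently; the difference between the two cores is not broken down here. In this assay compound 3 gives 50 nM.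

Compound 4 `COc1cc(OC[C@H](C)COc2ccc(C(=O)CC(C)(C)C)c(O)c2C)ccc1C(=O)O` has not yet been measured. It differs from compound 3 in one place: methoxy in place of chloro on an aromatic carbon. Within the data shown here, this is the same kind of change as the one from compound 1 to compound 2, though not the same: both times the methoxy is ortho to a carboxy group, but in compound 2 it is para to a large group, while in compound 4 it is meta to a large group. Because the earlier step of a 6.7-fold lower number from compound 1 to compound 2 (0.83 log units; beyond the scatter) lay beyond the scatter, compound 4 is expected to give a lower number than compound 3, with a step of a 3.3-fold lower number from compound 3 to compound 4 (0.52 log units; beyond the scatter), taken as somewhat smaller since the surroundings of the change differ. The estimate for compound 4 is 15 nM, expected to fall between 5 nM and 45 nM.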

Compound 4, half-maximal effective concentration: 194 nM
Compound 4: middle estimate off by 13-fold (1.11 log units), on the low side; the measured number lies above the stated range.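

In this assay, methoxy in place of chloro gives a 3.9-fold higher number from compound 3 to compound 4 (0.59 log units; beyond the scatter), so the change that lowered the number on the core of compound 1 raises it on the core of compound 3, and the two results clearly disagree: the same change on two cores in this assay, a 6.7-fold lower number (0.83 log units; beyond the scatter) from compound 1 to compound 2 and a 3.9-fold higher number (0.59 log units; beyond the scatter) from compound 3 to compound 4, 26-fold (1.41 log units) apart, beyond the scatter of two such steps

This shows that, in this series, the outcome of this change on one core cannot simply be carried over to another, not even its direction. It does not show which structural difference between the two cores separates the results or why they part ways, and two pairs of compounds are too few to give a rule for any further core.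

The compounds shown leave open how other groups, such as fluoro or ethoxy, would behave in place of chloro on each of the two cores. They also leave open whether a tetrazole in place of the carboxy group would alter the contrast between these two cores.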